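The source may report more compounds than this note shows. Statements on the series, on what has been measured and on what is new or still open speak of the compounds shown alone.

Measured compounds in an ADME assay on cells (Hepatocyte, Homo sapiens) for pharmacokinetics, read by LC-MS, with a stated time of 90 min, tested at 1 uM; a higher number here means faster removal of the compound, a lower number slower removal:

Compound 1 `O=C(CCCCCNc1c(Nc2ccc(C(F)(F)F)cc2)c(=O)c1=O)NO` gives 11 uL/min.
Compound 2 `CC(CCCCC(=O)NO)Nc1c(Nc2ccc(C(F)(F)F)cc2)c(=O)c1=O` gives 21 uL/min.
Compound 3 `CCC(CCCCC(=O)NO)Nc1c(Nc2ccc(C(F)(F)F)cc2)c(=O)c1=O` gives 25 uL/min.

Compound 3 stands at the highest of the three numbers. Its nearest neighbour is compound 2, with a 1.2-fold higher number from compound 2 to compound 3 (0.08 log units; within the scatter), so the two cannot be told apart. Its furthest is compound 1, with a 2.3-fold higher number from compound 1 to compound 3 (0.36 log units; beyond the scatter), a modest step that does clear the scatter.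

The next compound, compound 4 `CC(C)C(CCCCC(=O)NO)Nc1c(Nc2ccc(C(F)(F)F)cc2)c(=O)c1=O`, differs from compound 3 by methyl in place of hydrogen on a saturated chain carbon bound to two saturated chain carbons. The three steps already seen all concern growth of the same branch on the chain carbon bound to the ring nitrogen: hydrogen to methyl, a 1.9-fold higher number from compound 1 to compound 2 (0.28 log units; within the scatter); hydrogen to ethyl, a 2.3-fold higher number from compound 1 to compound 3 (0.36 log units; beyond the scatter); methyl to ethyl, a 1.2-fold higher number from compound 2 to compound 3 (0.08 log units; within the scatter). Each addition of one carbon to this branch has given a small rise, only the sum of two such additions reaching beyond the scatter. One further carbon on the branch is therefore expected to give at most a small further rise, likely within the scatter; a flat result is nearly as probable.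

Compound 4 is estimated at 30 uL/min, with a range of 15 uL/min to 60 uL/min, which is expected to amount to a 1.2-fold higher number from compound 3 to compound 4 (0.08 log units; within the scatter).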

Compound 4, intrinsic clearance in a liver preparation (reported as CLH), per the amount of preparation that the assay uses: 27 uL/min
Beside the measured number, compound 4's estimate is 1.1-fold (0.05 log units) above it, and the stated range covers the measured number.
By their numbers in this assay, from the lowest: compounds 1, 2, 3 and 4 (each within the scatter of the next, the first and the last beyond it).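

In this assay, isopropyl on the saturated chain carbon bound to a nitrogen on an aromatic ring and a saturated chain carbon cannot be told apart from ethyl or methyl there, with a 1.1-fold higher number from compound 3 to compound 4 (0.03 log units; within the scatter) and a 1.3-fold higher number from compound 2 to compound 4 (0.11 log units; within the scatter). Only the comparison with hydrogen at this position clears the scatter, with a 2.5-fold higher number from compound 1 to compound 4 (0.39 log units; beyond the scatter), a modest step close in size to a 2.3-fold higher number from compound 1 to compound 3 (0.36 log units; beyond the scatter), so the series shows no further separation among the three branches and no sharp penalty for branching at the added carbon. Methyl in place of hydrogen, read at two places on the series, gives steps that agree within the scatter: the same change on two cores in this assay, a 1.9-fold higher number (0.28 log units; within the scatter) from compound 1 to compound 2 and a 1.1-fold higher number (0.03 log units; within the scatter) from compound 3 to compound 4, 1.8-fold (0.25 log units) apart, within the scatter of two such steps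

From the compounds shown here alone, whether this flat behaviour extends to a longer chain such as n-butyl, to a cyclopropyl or phenyl group, or to a branch carrying an amine or a carboxylic acid remains open. The compounds shown also do not tell which part of the structure the removal in this assay acts on, or whether the modest gap from compound 1 would hold on a different core.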